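A ring-free dipropylamino group enters at compound 4

The compounds below may be only part of what the source reports. "The series", "measured", "known", "first", "only" and "open" are said of these compounds alone.

In an ADME assay on Huh7.5.1 cells (Homo sapiens) for cytotoxicity, read by ATP content, with a stated time of 48 h (a higher number here means that more compound is tolerated, a lower number that less compound is tolerated), compound 1 (`Cc1ccccc1-c1nc(CN2CCC(C(=O)NCCCN3CC(C)(C)CC(C)(C)C3)CC2)c(C)o1`) gives 4380 nM, compound 2 (`Cc1ccccc1-c1nc(CN2CCC(C(=O)NCCCN3CCCC(C(C)C)C3)CC2)c(C)o1`) gives 5820 nM and compound 3 (`Cc1ccccc1-c1nc(CN2CCC(C(=O)NCCCN3CC4CCCC(C4)C3)CC2)c(C)o1`) gives 10900 nM. Compound 3 thus sits level with one neighbour and clear of the other: the data show a 1.9-fold higher number from compound 2 to compound 3 (0.27 log units; within the scatter), but a 2.5-fold higher number from compound 1 to compound 3 (0.40 log units; beyond the scatter). Compound 4 (`CCCN(CCC)CCNC(=O)C1CCN(Cc2nc(-c3ccccc3C)oc2C)CC1`) carries dipropylamino, and the change is a group of 7 heavy atoms (6 carbon, 1 nitrogen; no ring) in place of a group of 10 heavy atoms (9 carbon, 1 nitrogen; one six-membered non-aromatic ring of carbon only, one six-membered non-aromatic ring with 1 hetero atom), on a saturated chain carbon, two bonds along the chain from an amide-type nitrogen. Among the measured compounds shown here, no measured step tests an open-chain group, so the guides are only the earlier swaps at this end of the molecule, which stayed small, such as a 1.3-fold higher number from compound 1 to compound 2 (0.12 log units; within the scatter). A step beyond the scatter is therefore not expected, and the estimated step is a 1.1-fold higher number from compound 3 to compound 4 (0.04 log units; within the scatter). For compound 4 the expected value is 12000 nM, with an estimated range of 5000 nM to 30000 nM.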

Compound 4, half-maximal cytotoxic concentration: 30500 nM
Compound 4: middle estimate off by 2.5-fold (0.41 log units), on the low side, outside the stated range (above it).
By their numbers in this assay, from the lowest: compounds 1, 2 and 3 (each within the scatter of the next, the first and the last beyond it); then compound 4.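

Replacing the ring-bearing groups with the open-chain dipropylamino group moves the number in this assay beyond the scatter in all three comparisons: a 2.8-fold higher number from compound 3 to compound 4 (0.45 log units; beyond the scatter), a 5.2-fold higher number from compound 2 to compound 4 (0.72 log units; beyond the scatter) and a 7.0-fold higher number from compound 1 to compound 4 (0.84 log units; beyond the scatter). Even the smallest of these exceeds every step among compound 1, compound 2 and compound 3, so this position can respond more strongly than those compounds showed. Nothing available explains the rise.

The loss of the ring and the shorter attachment, two bonds along the chain from an amide-type nitrogen, change together, so their shares remain unseparated. From the compounds shown here alone, how a diethylamino or dibutylamino group would compare also stays open.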